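This account rests on a few compounds, and the source may have more. Where it says the series, first, only, none or still open, it means among the compounds named here.

Compound 3 `CCC1(Cc2ccccc2)OS(=O)(=O)C=C1NCc1ccccc1` sits at the higher of the two plain numbers recorded in an ADME assay on HEL cells (Homo sapiens) for cytotoxicity, with a stated time of 3 days (on this read-out lower numbers stand for higher toxicity in this test and higher numbers for lower toxicity in this test), where compound 3 gives 92000 nM and compound 1 `CCC1(Cc2ccccc2)OS(=O)(=O)C=C1OCc1ccc(C)cc1` gives 41500 nM. Compound 2 `CCC1(Cc2ccccc2)OS(=O)(=O)C=C1OC` reaches only the limit of this assay, at > 200000 nM. Two measured steps frame the change to compound 4 `CCC1(Cc2ccccc2)OS(=O)(=O)C=C1OCC=C(C)C`, described by (3-methylbut-2-en-1-yl)oxy in place of benzylamino on a double-bonded ring carbon. Replacing the 4-methylphenyl with hydrogen gave an at least 4.8-fold higher number from compound 1 to compound 2 (0.68 log units; beyond the scatter), and exchanging methoxy for benzylamino gave an at least 2.1-fold lower number from compound 2 to compound 3 (0.33 log units; beyond the scatter); one value of that pair rests on (the limit of > 200000 nM in this assay, at which 1 of the 3 values shown sits). A (3-methylbut-2-en-1-yl)oxy group is an ether, as in compound 1 and compound 2, so a modest lower number is expected, a 1.5-fold lower number from compound 3 to compound 4 (0.19 log units; within the scatter). Compound 4 is estimated to give 60000 nM, within 25000 nM to 150000 nM.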

Compound 4, half-maximal cytotoxic concentration: 112000 nM
Estimate against measurement, compound 4: 1.9-fold (0.27 log units) below; low and high end bracket the measured number.
By their numbers in this assay, from the lowest: compound 1; then compounds 3 and 4 (each within the scatter of the next). At a limit, above all of these: compound 2.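

In this assay, exchanging benzylamino, with its aromatic ring, for (3-methylbut-2-en-1-yl)oxy, with no ring, on this double-bonded ring carbon leaves the read-out within the scatter (a 1.2-fold higher number from compound 3 to compound 4 (0.09 log units; within the scatter)), so an ether is not needed here for numbers of this size. What sits at the end of the ether still matters (a 2.7-fold higher number from compound 1 to compound 4 (0.43 log units; beyond the scatter)). The comparison with the methoxy ether (an at least 1.7-fold lower number from compound 2 to compound 4 (0.25 log units; that floor lies within the scatter)) gives only a floor within the scatter, and it rests on a limit: the limit of > 200000 nM in this assay, at which 1 of the 4 values shown sits.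

From the compounds shown here alone, whether a simple amine such as dimethylamino or a longer saturated chain such as hexyloxy at this position would stay in the same range remains open.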